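Benzamide to Phenylurea on a Biphenyl Piperidine Scaffold

This account rests on a few compounds, and the source may have more. Where it says the series, first, only, none or still open, it means among the compounds named here.

Of the compounds shown here, three have been measured in a functional assay on CHO cells for antagonist activity at Orexin/Hypocretin receptor type 1 (Homo sapiens), read by FLIPR; on this read-out lower numbers stand for stronger inhibition and higher numbers for weaker inhibition. Compound 1 `O=C(c1ccccc1-c1ccccc1)N1CCCCC1CCOc1ccc(F)cc1` gives 5.01 nM, compound 2 `O=C(c1cccc2ccccc12)N1CCCC[C@H]1CCOc1ccc(F)cc1` gives 6.31 nM, and compound 3 `O=C(NC[C@@H]1CCCCN1C(=O)c1ccccc1-c1ccccc1)c1ccccc1` gives 7.94 nM. Compound 3 shows the highest of the three numbers, but its gap to compound 2 and its gap to compound 1 both lie within the scatter of repeated measurements, so the three results cannot be told apart with confidence.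

Compound 4 `O=C(NC[C@@H]1CCCCN1C(=O)c1ccccc1-c1ccccc1)Nc1ccccc1` has not yet been measured. It differs from compound 3 in a single place: anilino in place of phenyl on a carbonyl carbon. The carbonyl carbon that carried the phenyl now carries an anilino group, which brings one more hydrogen-bond donor into the molecule while the rest of the structure stays the same.

Within the data shown here, no measured pair among compounds 1 to 3 involves this particular exchange, so there is no directly comparable step to lean on. The change is modest in size and keeps the aromatic ring, so the expected step from compound 3 to compound 4 in this assay is a 1.9-fold higher number from compound 3 to compound 4 (0.28 log units; within the scatter), a shift that may not clearly exceed the scatter. On that basis, compound 4 is estimated to give 15 nM in this assay, with a plausible range from 4 nM to 60 nM.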

Compound 4, inhibition constant: 1 nM
For compound 4 the middle estimate is 15-fold (1.18 log units) above the measured one, outside the stated range (below it).
By their numbers in this assay, from the lowest: compound 4; then compounds 1, 2 and 3 (each within the scatter of the next).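

In this assay, anilino in place of phenyl on a carbonyl carbon gives a 7.9-fold lower number from compound 3 to compound 4 (0.90 log units; beyond the scatter), the first difference among these compounds that lies clearly beyond the scatter. This shows that the position is sensitive to a small change, since the carbon-only aromatic ring stays and the rest of the structure stays the same, yet the number still moves clearly. The entering anilino brings a nitrogen and has 1 hydrogen-bond donor against 0 for phenyl, but this single pair cannot separate those two differences from the change in group size, and no supporting measurement points to a cause.

The compounds shown leave open whether the nitrogen itself matters, which benzyl or phenoxy on the same carbonyl carbon could test, and whether its hydrogen matters, which an N-methylanilino group could test by keeping the nitrogen while removing that hydrogen. They also leave open how much room this position allows, for example whether a fluoro or methoxy group on the anilino ring, or a longer chain in place of anilino, would keep the lower number.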